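The source may hold more compounds than are shown below. What is called first, only, known or untested is meant among the compounds shown, and "the series" means these compounds.

Of the compounds shown here, three have so far been tested in a functional assay on DU-145 cells (Homo sapiens) for antiproliferative activity, read by MTT assay, with a stated time of 24 h; on this read-out higher numbers stand for weaker inhibition and lower numbers for stronger inhibition. Compound 1, `COc1ccc(-c2cc(/C=C/C(=O)c3cc(OC)c(OC)c(OC)c3)nc3cc(-c4ccccc4)nn23)cc1OC`, gives 8300 nM in this assay. Compound 2, `COc1ccc(-c2cc(/C=C/C(=O)c3ccc(C)cc3)nc3cc(-c4ccccc4)nn23)cc1OC`, gives 26800 nM in this assay. Compound 3, `COc1cc(-c2cc(C(=O)/C=C/c3ccc(C)cc3)nc3cc(-c4ccccc4)nn23)cc(OC)c1OC`, gives 21900 nM in this assay.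

Compound 2 and compound 1 differ in a single place: 3,4,5-trimethoxyphenyl in place of 4-methylphenyl on a carbonyl carbon That change produced a 3.2-fold lower number from compound 2 to compound 1 (0.51 log units; beyond the scatter). Compound 3 differs from compound 2 in more than one place, so the difference between the two cores is not broken down here; the values of compound 3 and compound 2 lie within the usual scatter of each other, whereas the value of compound 3 is higher than that of compound 1 by more than the scatter.

Compound 4, `COc1cc(/C=C/C(=O)c2cc(-c3cc(OC)c(OC)c(OC)c3)n3nc(-c4ccccc4)cc3n2)cc(OC)c1OC`, has not yet been measured. It differs from compound 3 as follows: 3,4,5-trimethoxyphenyl in place of 4-methylphenyl on a double-bonded chain carbon bound to a double-bonded chain carbon This is the same kind of change as that made from compound 2 to compound 1, but not the same: in the earlier pair the entering group sits on a carbonyl carbon whose other neighbour is a double-bonded chain carbon, while here it sits on a double-bonded chain carbon bound to a double-bonded chain carbon. Set against the earlier step, the step in this assay is expected to be a 2.7-fold lower number from compound 3 to compound 4 (0.44 log units; beyond the scatter), an expectation that rests on a 3.2-fold lower number from compound 2 to compound 1 (0.51 log units; beyond the scatter). Compound 4 is therefore estimated at 8000 nM, in a range expected to run from 3000 nM to 20000 nM.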

Compound 4, half-maximal inhibitory concentration: 17900 nM
Compound 4: the middle estimate sits 2.2-fold (0.35 log units) below what was measured; measured number inside the range.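

Placing 3,4,5-trimethoxyphenyl in place of 4-methylphenyl on a double-bonded chain carbon bound to a double-bonded chain carbon gives a 1.2-fold lower number from compound 3 to compound 4 (0.09 log units; within the scatter) in this assay and so has no effect here that stands clear of the normal variation between repeat measurements. Although the same change had a clear effect on the other core and no clear effect on this one, the two results cannot be told apart: the same change on two cores in this assay, a 3.2-fold lower number (0.51 log units; beyond the scatter) from compound 2 to compound 1 and a 1.2-fold lower number (0.09 log units; within the scatter) from compound 3 to compound 4, 2.6-fold (0.42 log units) apart, within the scatter of two such steps. This does not show that the change carries over from one core to the other, nor does it show that it fails to carry over, since one pair on each core cannot separate a real difference between the cores from ordinary variation.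

The compounds shown leave open whether a single methoxy group, or a different kind of group such as an amine or a carboxylic acid, would produce a step beyond the scatter on both cores. They also leave open what would happen if the phenyl group shared by all four compounds gave way to one of these groups, and more pairs on each core would be needed to settle how well any such change carries over.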